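The source may hold more compounds than are shown below. What is called first, only, known or untested is meant among the compounds shown, and "the series" means these compounds.

Among the compounds with values here, the two compounds measured so far share one core. Compound 1 `CCN(CC)C(=O)CN(c1ccc(C)cc1)S(=O)(=O)c1ccc(C#N)cc1` in a functional assay on CHO cells for inhibition of Orexin receptor type 2 (Homo sapiens), read by FLIPR and calcium flux (on this read-out lower numbers stand for stronger inhibition and higher numbers for weaker inhibition), gives 1190 nM. Within the data shown here, compound 2 `CCN(CC)C(=O)CN(c1ccc(C)cc1)S(=O)(=O)c1ccc(Br)cc1` in this assay gives 142 nM, and the step of an 8.4-fold lower number from compound 1 to compound 2 (0.92 log units; beyond the scatter) is the only step measured. Among the measured compounds shown here, compound 2 thus stands lowest of the two numbers, with compound 1 as its only neighbour. Compound 3 `CCN(CC)C(=O)CN(c1ccc(C)cc1)S(=O)(=O)c1ccccc1F` differs from compound 2 by 2-fluorophenyl in place of 4-bromophenyl on a sulfonyl sulfur. For the measured compounds named here, the step from compound 1 to compound 2 bears on the same ring attached to the sulfonyl sulfur and shows that a change on that ring can move the number by a modest amount, but it does not cover an exchange for 2-fluorophenyl, and no other measured step does. The number for compound 3 is therefore expected to rise, and the expected step is a 4.2-fold higher number from compound 2 to compound 3 (0.63 log units; beyond the scatter). The estimate for compound 3 in this assay is 600 nM, within 150 nM to 2500 nM.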

Compound 3, half-maximal inhibitory concentration: 3370 nM
Estimate against measurement, compound 3: 5.6-fold (0.75 log units) below; the whole stated range lies below it.
By their numbers in this assay, from the lowest: compound 2; then compound 1; then compound 3.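

On the sulfonyl sulfur, the exchange of 4-bromophenyl for 2-fluorophenyl produces a large move in this assay (a 24-fold higher number from compound 2 to compound 3 (1.38 log units; beyond the scatter)), so this position can shift the number further than the earlier change of bromo for cyano showed. The same group also falls short of the 4-cyanophenyl group (a 2.8-fold higher number from compound 1 to compound 3 (0.45 log units; beyond the scatter)), which makes 2-fluorophenyl the weakest of the three groups shown here and 4-bromophenyl the strongest. Nothing available explains this order.

Because 2-fluorophenyl differs from 4-bromophenyl in both its halogen and its name position, the compounds shown cannot separate the two, and 4-fluorophenyl, 2-bromophenyl and plain phenyl would each bear on that question. They also leave open how the number responds on this sulfonyl sulfur to an amine or a carboxylic acid on the ring.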